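The compounds below may be only part of what the source reports. "The series", "measured", "known", "first", "only" and "open" are said of these compounds alone.

Measured in a physicochemical assay for solubility, in phosphate buffer, measured as kinetic solubility, with a stated time of 1 h, at pH 7.4; on this read-out higher numbers stand for higher solubility and lower numbers for lower solubility:
- Compound 1 `CCNC(=O)Nc1ccc(-c2nc(CS(C)(=O)=O)cc([C@]34CCOC[C@H]3C4)n2)cc1`: 96 ug/mL
- Compound 2 `CNCC(=O)Nc1ccc(-c2nc(CS(C)(=O)=O)cc([C@@]34CCOC[C@@H]3C4)n2)cc1`: 167 ug/mL
- Compound 3 `CNCC(=O)Nc1ccc(-c2nc(C(C)(C)S(C)(=O)=O)cc([C@]34CCOC[C@H]3C4)n2)cc1`: 217 ug/mL

On this assay, compound 3 at 217 ug/mL cannot be told apart from compound 2, as the two values lie within the scatter of each other. The gap between compound 3 and compound 1 is beyond the scatter, and compound 3 holds the higher number of that pair.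

The next compound is compound 4 `CNCC(=O)Nc1ccc(-c2nc(CS(C)(=O)=O)cc([C@]34CCOC[C@H]3C4)n2)cc1`, where (methylsulfonyl)methyl takes the place of 1-methyl-1-(methylsulfonyl)ethyl on an aromatic carbon ((methylsulfonyl)methyl in place of 1-methyl-1-(methylsulfonyl)ethyl on an aromatic carbon). Within the data shown here, no measured pair of compounds isolates this change, so the data offer no direct precedent for it. The nearest guide is compound 2, which also carries (methylsulfonyl)methyl and gives 167 ug/mL. A small downward step within the scatter is therefore expected, and a 1.3-fold lower number from compound 3 to compound 4 (0.12 log units; within the scatter) is the estimated size of it. Compound 4 is expected at 165 ug/mL, with an estimated range of 90 ug/mL to 290 ug/mL.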

Compound 4, solubility: 158 ug/mL
Estimate against measurement, compound 4: 1.0-fold (0.02 log units) above, and the stated range covers the measured number.
By their numbers in this assay, from the lowest: compounds 1, 4, 2 and 3 (each within the scatter of the next, the first and the last beyond it).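

Among these compounds, compound 4 gives the first direct reading of this change on the aromatic carbon: with (methylsulfonyl)methyl in place of 1-methyl-1-(methylsulfonyl)ethyl, this assay shows a 1.4-fold lower number from compound 3 to compound 4 (0.14 log units; within the scatter), so the two groups cannot be told apart here. Configuration can now be read on its own as well, and a 1.1-fold lower number from compound 2 to compound 4 (0.02 log units; within the scatter) shows no difference that stands out from the scatter, a clean comparison for this reason: the fact that compounds 2 and 4 differ only in the configuration as drawn The exchange of ethylamino for (methylamino)methyl on a carbonyl carbon, seen as a 1.6-fold higher number from compound 1 to compound 4 (0.22 log units; within the scatter), likewise stays within the scatter.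

The compounds shown leave open whether a carboxylic acid or a longer sulfonyl chain on that aromatic carbon would give a step beyond the scatter. They also leave open what a tertiary amine such as dimethylamino would do on the chain at the carbonyl carbon.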